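The source may hold more compounds than are shown below. What is called first, only, known or untested is meant among the compounds shown, and "the series" means these compounds.

Compound 1 `CN1CCN(CCNCc2cn(-c3ccc(F)cc3F)nc2-c2ccc(S(=O)(=O)N(C)C)cc2)CC1`: > 20000 nM
Compound 2 `CN1CCN(CCNCc2cn(-c3ccc(F)cc3F)nc2-c2ccc(C(F)(F)F)cc2)CC1`: 20000 nM

In an ADME assay on Huh-7 cells (Homo sapiens) for cytotoxicity (on this read-out lower numbers stand for higher toxicity in this test and higher numbers for lower toxicity in this test), compound 1 gives > 20000 nM, which is a limit of the assay and not a number. For the measured compounds named here, compound 2 gives 20000 nM, the only number among the two values; the step of a number no higher from compound 1 to compound 2 (the limit leaves the size open) starts from that limit (the limit of > 20000 nM in this assay, at which 1 of the 2 values shown sits), so its size cannot be read. Compound 3 `CN1CCN(CCNCc2cn(-c3ccc(F)cc3F)nc2-c2ccc(N(C)C)cc2)CC1` differs from compound 2 by dimethylamino in place of trifluoromethyl on an aromatic carbon. Going by the values given here, no measured step covers a dimethylamino group, and the one step known is of unreadable size. For compound 3 the expected step of no change at the digits printed from compound 2 to compound 3 (within the scatter) therefore stays within the scatter, and compound 3 is estimated at 20000 nM, within 8000 nM to 40000 nM.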

Compound 3, half-maximal cytotoxic concentration: > 20000 nM
Compound 3 ended at the assay's limit; the forecaster's own chance of this, stated with the estimate: 50%; the middle value sits exactly at the limit.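

In this assay compound 3 gives > 20000 nM, a limit and not a number, so dimethylamino joins dimethylsulfamoyl as a second group at this position that ends at the limit. The steps that link compound 3 to compound 1 and compound 2 cannot be read. Most of this small set is capped: the limit of > 20000 nM in this assay, at which 2 of the 3 values shown sit.

As far as these compounds go, how far compound 1 and compound 3 actually lie from compound 2 stays open. Dimethylamino in place of trifluoromethyl gives a number no lower from compound 2 to compound 3 (the limit leaves the size open).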